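The source may report more compounds than this note shows. Statements on the series, on what has been measured and on what is new or still open speak of the compounds shown alone.

Compound 3 `CC(C)(C)NC(=O)NCCS(=O)(=O)NC(=O)c1ccc(Nc2nc(NC3(c4ccc(Cl)cc4)CC3)nc(OCC(F)(F)F)n2)cc1` stands in an ADME assay on microsomes from liver (Homo sapiens) for metabolic stability, with a stated time of 10 min (a lower number here means that less of the compound is left, a higher number that more of the compound is left), at 96%, the lowest of the three numbers in hand, though every gap to the other two lies within the scatter. Compound 1 `O=C(NS(=O)(=O)c1ccc(F)cc1)c1ccc(Nc2nc(NC3(c4ccc(Cl)cc4)CC3)nc(OCC(F)(F)F)n2)cc1` gives 100% in this assay, and compound 2 `CC(C)S(=O)(=O)NC(=O)c1ccc(Nc2nc(NC3(c4ccc(Cl)cc4)CC3)nc(OCC(F)(F)F)n2)cc1` gives 100%. The step of a number 4 percentage points lower from compound 1 to compound 3 (within the scatter) and the step of a number 4 percentage points lower from compound 2 to compound 3 (within the scatter) both remain within the scatter, as does no change at the digits printed from compound 1 to compound 2 (within the scatter). The three compounds differ only in the group on the sulfonyl sulfur, and none of those exchanges moved the read-out beyond the scatter.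

Compound 4 `CC(C)C(=O)NCCS(=O)(=O)NC(=O)c1ccc(Nc2nc(NC3(c4ccc(Cl)cc4)CC3)nc(OCC(F)(F)F)n2)cc1` has not yet been measured. It differs from compound 3 in one place: isopropyl in place of (tert-butyl)amino on a carbonyl carbon. Among the compounds with values here, no measured step touches this part of the molecule; the steps that exist all concern the group on the sulfonyl sulfur, and each was small. Given that compound 3 already sits at 96% and that the only known steps in this assay stayed within the scatter, the step of a number 2 percentage points lower from compound 3 to compound 4 (within the scatter) is expected to stay within the scatter too, with no direction that can be called. For compound 4 the estimate in this assay is 94%, with a range from 82% to 100%.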

Compound 4, percent of the compound remaining: 86%
The estimate for compound 4 lay 8 percentage points above the measured number; the measured number falls inside the stated range.
By their numbers in this assay, from the lowest: compounds 4, 3, 1 and 2 (each within the scatter of the next, the first and the last beyond it).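

In this assay, the exchange of (tert-butyl)amino for isopropyl on a carbonyl carbon gives a number 10 percentage points lower from compound 3 to compound 4 (within the scatter), so this single change cannot be told apart from the usual spread of repeated measurements. Within the data shown here, the same compound nevertheless gives the first steps in the set that pass the scatter: a 2-((isopropylcarbonyl)amino)ethyl group on the sulfonyl sulfur gives a number 14 percentage points lower from compound 2 to compound 4 (beyond the scatter) and a number 14 percentage points lower from compound 1 to compound 4 (beyond the scatter), both modest, whereas the chain carrying the (tert-butyl)carbamoyl group in compound 3 stayed within the scatter of those same two compounds. No other measurement in hand bears on why the two chains differ in this way.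

The compounds shown leave open whether the gap belongs to the nitrogen that leaves or to the carbon groups on the carbonyl, since both change together; a tert-butyl group directly on the carbonyl carbon, or an isopropylamino group there, would separate the two. They also leave open how a longer chain on the sulfonyl sulfur, or a carboxylic acid at the end of it, would read in this assay.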